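Swapping an amide for a sulfonamide on the shared core

The compounds below may be only part of what the source reports. "The series", "measured", "known", "first", "only" and "open" are said of these compounds alone.

Compound 2 `CCCCCC(=O)Nc1ccc2c(c1)[C@@H](c1ccccc1)[C@@H](O)[C@](CC)(CCCC)CS2(=O)=O` gives 300 nM in an assay on cells for inhibition of ileal sodium/bile acid cotransporter (Homo sapiens); a lower number here means a stronger inhibitor, a higher number a weaker inhibitor. Going by the values given here, it stands at the upper end of the two numbers measured so far, but the gap to compound 1 `CCCC[C@]1(CC)CS(=O)(=O)c2ccc(NO)cc2[C@@H](c2ccccc2)[C@H]1O`, which gives 260 nM in this assay, lies within the scatter, so the two cannot be told apart. Compound 3 `CCCC[C@]1(CC)CS(=O)(=O)c2ccc(NS(C)(=O)=O)cc2[C@@H](c2ccccc2)[C@H]1O` differs from compound 2 in one place: methylsulfonyl in place of pentylcarbonyl on a nitrogen on an aromatic ring. Among the compounds with values here, the only measured step that bears on this position is a 1.2-fold higher number from compound 1 to compound 2 (0.06 log units; within the scatter), which shows that exchanging one substituent on that nitrogen for another left the number essentially unchanged. On that basis a further exchange on the same nitrogen is expected to move the number little, and the step of no change at the digits printed from compound 2 to compound 3 (within the scatter) is estimated to stay within the scatter. Compound 3 is therefore expected to give about 300 nM in this assay, with a range from 100 nM to 900 nM.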

Compound 3, half-maximal inhibitory concentration: 600 nM
Beside the measured number, compound 3's estimate is 2.0-fold (0.30 log units) below it, within the range that was stated.
By their numbers in this assay, from the lowest: compounds 1, 2 and 3 (each within the scatter of the next, the first and the last beyond it).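

In this assay, replacing pentylcarbonyl with methylsulfonyl on this nitrogen gives a 2.0-fold higher number from compound 2 to compound 3 (0.30 log units; within the scatter), so an amide and a sulfonamide at this position cannot be told apart on this pair alone. Going by these compounds alone, the step of a 2.3-fold higher number from compound 1 to compound 3 (0.36 log units; beyond the scatter) is the first at this position to pass beyond the scatter, although only modestly, and it shows that the substituent on this nitrogen can shift the number. Nothing available explains why the methylsulfonyl and hydroxy compounds separate in this way.

The change from compound 2 to compound 3 alters both the carbonyl-to-sulfonyl link and the chain at once, so a methylcarbonyl or pentylsulfonyl group would be needed to separate those two contributions. As far as these compounds go, it also remains open whether a plain amine on this nitrogen, or a longer chain on the sulfonyl group, would stay within this narrow band of numbers.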